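The source may hold more compounds than are shown below. What is called first, only, known or untested is meant among the compounds shown, and "the series" means these compounds.

Measured so far:
compound 1 `Cc1ccccc1S(=O)(=O)Nc1ccc2oc(-c3ccccc3)nc2c1` — in an ADME assay on HEK293 cells (Homo sapiens) for cytotoxicity, read by resazurin assay, with a stated time of 48 h (a lower number here means that less compound is tolerated, a higher number that more compound is tolerated), compound 1 gives 57000 nM.
compound 2 `O=S(=O)(Nc1ccc(-c2nc3ccccc3o2)cc1)c1cccc(O)c1` — in this assay compound 2 reaches only a limit of the assay, > 100000 nM.

Going by the values given here, compound 1 thus holds the only real number here; the other value is a limit (the limit of > 100000 nM in this assay, at which 1 of the 2 values shown sits). Compound 3 `O=S(=O)(Nc1ccc2oc(-c3ccccc3)nc2c1)c1ccccc1Cl` differs from compound 1 in one place: chloro in place of methyl on an aromatic carbon. Among the compounds with values here, no measured pair shows what such a change does, so in this assay a step of no more than the usual scatter is expected, in no set direction. Compound 3 is therefore expected to give about 50000 nM in this assay, most likely between 20000 nM and 100000 nM. This amounts to an expected step of a 1.1-fold lower number from compound 1 to compound 3 (0.06 log units; within the scatter).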

Compound 3, half-maximal cytotoxic concentration: 73000 nM
For compound 3 the middle estimate is 1.5-fold (0.16 log units) below the measured one; the measured number falls inside the stated range.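

In this assay the change from 2-methylphenyl to 2-chlorophenyl gives a 1.3-fold higher number from compound 1 to compound 3 (0.11 log units; within the scatter) and so, at this position, the two groups cannot be told apart by how much compound the cells tolerate. This is the first measured pair for this change, and nothing shown here accounts for the step. Still open, on these data alone, is whether a group of another kind at this position, such as an amine or a carboxylic acid, would move the number beyond the scatter. As far as these compounds go, the same swap elsewhere on this ring also remains untested by these compounds.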